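The compounds below may be only part of what the source reports. "The series", "measured", "known", "first", "only" and "open" are said of these compounds alone.

Values in a functional assay on A549 cells (Homo sapiens) for cytotoxicity, read by MTT assay, with a stated time of 72 h; a higher number here means a weaker inhibitor, a lower number a stronger inhibitor:
- Compound 1 `O=S(=O)(c1ccccc1)c1nc2ccccc2nc1Nc1ccc(Cl)cc1`: 30700 nM
- Compound 2 `COc1ccc(Nc2nc3ccccc3nc2S(=O)(=O)c2ccc(C)cc2)cc1`: > 50000 nM (a limit of the assay)
- Compound 3 `COc1ccc(Nc2nc3ccccc3nc2S(=O)(=O)c2ccc(OC)cc2)cc1`: 8260 nM

Compound 3, at 8260 nM, holds the lower of the two actual numbers in this assay, and the gap to compound 1, at 30700 nM, lies beyond the scatter. The value of compound 2 is a limit. Compound 4 `COc1ccc(S(=O)(=O)c2nc3ccccc3nc2Nc2ccc(Cl)cc2)cc1` departs from compound 3 by one exchange, chloro in place of methoxy on an aromatic carbon, para to a large group: chloro in place of methoxy on an aromatic carbon. Among the measured compounds shown here, the only measured step, an at least 6.0-fold lower number from compound 2 to compound 3 (0.78 log units; beyond the scatter), is a different exchange, methoxy in place of methyl, so it gives no direct size for this one. The closest guide is compound 1, which carries the same (4-chlorophenyl)amino group and gives 30700 nM. A modest rise is therefore expected, with the estimated step being a 1.7-fold higher number from compound 3 to compound 4 (0.23 log units; within the scatter). For compound 4 the expected value is 14000 nM, with an estimated range from 5000 nM to 40000 nM.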

Compound 4, half-maximal inhibitory concentration: 87300 nM
Compound 4: middle estimate off by 6.2-fold (0.79 log units), on the low side; measured number above the stated range.
By their numbers in this assay, from the lowest: compound 3; then compound 1; then compound 4.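

In this assay, the exchange on the amino-linked ring proves large: an 11-fold higher number from compound 3 to compound 4 (1.02 log units; beyond the scatter). Among the compounds shown here, the (4-methoxyphenyl)amino group therefore counts for far more in compound 3 than the earlier compounds could show, since their only measured step concerned the other aromatic ring. That other ring now also behaves differently: with (4-chlorophenyl)amino in place, methoxy instead of hydrogen gives a 2.8-fold higher number from compound 1 to compound 4 (0.45 log units; beyond the scatter), so a methoxy there brings no gain in this setting, unlike the step that ended at compound 3.

Compound 2 stands only as a limit and cannot be ordered against compound 4: the limit of > 50000 nM in this assay, at which 1 of the 4 values shown sits. The compounds shown leave open how a fluoro, an amine or a carboxylic acid would read at the place of the chloro, and whether methoxy on the amino-linked ring alone suffices.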